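Chloro to methoxy on the benzyl ring of compound 3

This account rests on a few compounds, and the source may have more. Where it says the series, first, only, none or still open, it means among the compounds named here.

In a functional assay on cells for positive allosteric modulation of G-protein coupled receptor 68 (Homo sapiens), read by a luciferase reporter and cAMP accumulation, with a stated time of 30 min, at pH 6.8 and pH 8.3, in the presence of a further agent that is not named here (on this read-out higher numbers stand for higher potency (the scale is a negative logarithm) and lower numbers for lower potency), three compounds have been measured so far:
compound 1 `CNc1nc(NCc2ccccc2)nc(-c2ccccc2CO)n1` gives 4.51;
compound 2 `CCOc1ccc(-c2nc(N)nc(NCc3ccccc3)n2)c(CO)c1` gives 4.37;
compound 3 `Nc1nc(NCc2ccccc2Cl)nc(-c2ccccc2CO)n1` gives 5.07.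

Compound 3 stands highest of the three. Compound 1 sits beyond the scatter below it, and compound 2 lies further still; neither pair differs in a single place, so their values are set side by side without a step. Compound 4 `COc1ccccc1CNc1nc(N)nc(-c2ccccc2CO)n1` differs from compound 3 by methoxy in place of chloro on an aromatic carbon. Among the compounds with values here, no measured step of this kind is at hand. The change is expected to cost little, and the step of a number 0.27 log units lower from compound 3 to compound 4 (within the scatter) is estimated to fall within the scatter or slightly below. Compound 4 is therefore expected to give 4.8, in a range from 4.3 to 5.3.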

Compound 4, negative logarithm of the antagonist equilibrium constant: 3.99
The estimate for compound 4 lay 0.81 log units above the measured number, and the stated range ends above it.
By their numbers in this assay, from the lowest: compound 4; then compounds 2 and 1 (each within the scatter of the next); then compound 3.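

In this assay, the change at this aromatic carbon, ortho to a large group, is not a tolerated swap: methoxy in place of chloro gives a number 1.08 log units lower from compound 3 to compound 4 (beyond the scatter), a large step. Within the data shown here, this is the first comparison that differs in one place, and it favours chloro over methoxy here, though it rests on this single pair. No available evidence accounts for the loss.

Going by these compounds, whether fluoro, bromo or methyl on this carbon would match chloro or fall towards methoxy remains open, as does whether ethoxy would lose still more.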